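A few compounds are considered here, and "the series" means these few. Any claim that something is new, unique, unknown or untested is made for them only; others in the source may bear on it.

Measured so far:
Compound 1 `CN(c1ccncc1)n1cccc1` in a functional assay on the whole organism with Mus musculus as the target (on this read-out lower numbers stand for an effect already at smaller amounts and higher numbers for an effect only at larger amounts of compound), gives > 20 mg/kg, a limit of the assay and not a number.
Compound 2 `CCCN(c1ccncc1)n1cccc1` in this assay gives > 20 mg/kg, again a limit.
Compound 3 `CN(c1ccncc1)n1cccc1C=O` in this assay gives > 20 mg/kg, also a limit.

The change from compound 1 to compound 2 is ethyl in place of hydrogen on a saturated chain carbon bound to a nitrogen on an aromatic ring. The size of that step, a step that the two limits leave unreadable from compound 1 to compound 2, stays hidden because all three values sit at the limit of > 20 mg/kg in this assay, at which 3 of the 3 values shown sit. The two cores differ by formyl in place of hydrogen on an aromatic carbon; its step, a step that the two limits leave unreadable from compound 1 to compound 3, is unreadable for the same reason, both compounds sitting at the limit of > 20 mg/kg in this assay, at which 3 of the 3 values shown sit.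

Compound 4 `CCCN(c1ccncc1)n1cccc1C=O` is not yet measured. Among the compounds with values here, it differs from compound 3 by ethyl in place of hydrogen on a saturated chain carbon bound to a nitrogen on an aromatic ring, the same change as the one from compound 1 to compound 2, at a place described in identical words. With nothing but limits on either side of that change, no direction can be read for it. The step from compound 3 to compound 4 is therefore expected to be small, a step that the limit leaves unreadable from compound 3 to compound 4, and most likely to end once more at a limit. Compound 4 is estimated at 30 mg/kg in this assay, with a range from 10 mg/kg to 100 mg/kg.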

Compound 4, dose for half-maximal effect: > 20 mg/kg
Compound 4 gave a limit, no number (the forecaster's own chance of this, stated with the estimate: 80%); the middle value does not contradict the limit.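

Compound 4 adds no readable step to compound 2 or compound 3 in this assay, because all the values are limits and not numbers: the limit of > 20 mg/kg in this assay, at which 4 of the 4 values shown sit.

The compounds shown leave open whether ethyl in place of hydrogen, or formyl in place of hydrogen on an aromatic carbon, changes the dose for half-maximal effect at all, and in which direction.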